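This account rests on a few compounds, and the source may have more. Where it says the series, first, only, none or still open, it means among the compounds named here.

Measured in a functional assay on HL-60 cells (Homo sapiens) for cytotoxicity, read by ELISA, with a stated time of 2 days; on this read-out lower numbers stand for stronger inhibition and higher numbers for weaker inhibition:
- compound 1 `Oc1cccc(-c2cc(-c3ccccc3)cc(-c3ccsc3)n2)c1`: 10300 nM
- compound 2 `Oc1ccc(-c2cc(-c3ccccc3)cc(-c3ccsc3)n2)cc1`: 3600 nM
- compound 3 `Oc1ccccc1-c1cc(-c2ccccc2)nc(-c2ccco2)c1`: 1900 nM

Compound 3, at 1900 nM, cannot be told apart from compound 2 within the usual scatter, while compound 1 stands clearly higher and so is weaker.

Compound 4 `Oc1cccc(-c2cc(-c3ccccc3)nc(-c3ccco3)c2)c1` has the same atoms as compound 3, joined differently: 3-hydroxyphenyl in place of 2-hydroxyphenyl on an aromatic carbon, opposite the ring nitrogen (3-hydroxyphenyl in place of 2-hydroxyphenyl on an aromatic carbon).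

For the measured compounds named here, no measured pair compares these two groups directly. The nearest evidence is a different swap on a different core, a 2.9-fold lower number from compound 1 to compound 2 (0.46 log units; beyond the scatter), where 4-hydroxyphenyl replaces 3-hydroxyphenyl. It shows that the hydroxyl position can shift this assay modestly. Going by the values given here, compound 1, the only measured compound with 3-hydroxyphenyl, gives 10300 nM, which points weakly towards a higher number.

A modest rise is therefore expected, an estimated 2.0-fold higher number from compound 3 to compound 4 (0.30 log units; within the scatter). For compound 4 the expected value is about 3800 nM, with an estimated range from 1300 nM to 11000 nM.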

Compound 4, half-maximal inhibitory concentration: 24000 nM
Beside the measured number, compound 4's estimate is 6.3-fold (0.80 log units) below it, and the stated range ends below it.
By their numbers in this assay, from the lowest: compounds 3 and 2 (each within the scatter of the next); then compound 1; then compound 4.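

The hydroxyl's place on this phenyl ring is far from a minor detail: in this assay, 3-hydroxyphenyl in place of 2-hydroxyphenyl, on the aromatic carbon opposite the ring nitrogen, gives a 13-fold higher number from compound 3 to compound 4 (1.10 log units; beyond the scatter). The two compounds hold the same atoms, so this pair isolates the placement of the hydroxyl, and it reaches further than the earlier step on a different core, a 2.9-fold lower number from compound 1 to compound 2 (0.46 log units; beyond the scatter), which was modest. No measurement shown here explains why this change has so large an effect.

From the compounds shown here alone, it remains open how 4-hydroxyphenyl would behave at this position on the core of compound 3. Also open, going by these compounds, is whether an amine or a carboxylic acid on this phenyl ring, in place of the hydroxyl, would hold the number of compound 3, 1900 nM.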